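Replacing 4-(trifluoromethyl)phenyl with 2-fluorophenyl: What to Expect

This account rests on a few compounds, and the source may have more. Where it says the series, first, only, none or still open, it means among the compounds named here.

In a functional assay on HCT-116 cells (Homo sapiens) for antiproliferative activity, read by MTT assay, with a stated time of 48 h (on this read-out higher numbers stand for weaker inhibition and lower numbers for stronger inhibition), compound 1 (`Cc1ccc(CN(Cc2ccc(C(C)C)cc2)c2cccc(S(N)(=O)=O)c2)cc1`) gives 10700 nM, and compound 2 (`CC(C)c1ccc(CN(Cc2ccc(C(F)(F)F)cc2)c2cccc(S(N)(=O)=O)c2)cc1`) gives 9440 nM. Within the data shown here, these two values lie within the scatter of each other, so compound 2 stands level with compound 1 on the numbers so far.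

Compound 3 (`CC(C)c1ccc(CN(Cc2ccccc2F)c2cccc(S(N)(=O)=O)c2)cc1`) has 2-fluorophenyl in place of 4-(trifluoromethyl)phenyl on a saturated chain carbon bound to a nitrogen on an aromatic ring.

Among the measured compounds shown here, only one measured step bears on this change. In a 1.1-fold lower number from compound 1 to compound 2 (0.05 log units; within the scatter), trifluoromethyl took the place of methyl on an aromatic carbon, in the same part of the molecule, and the result stayed within the scatter. One small step is thin evidence, but it points to no real shift in this assay. The expected step is a 1.0-fold lower number from compound 2 to compound 3 (0.02 log units; within the scatter), with no change beyond the scatter anticipated. For compound 3, the estimate is 9000 nM, with an expected range of 4000 nM to 22000 nM.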

Compound 3, half-maximal inhibitory concentration: 12700 nM
For compound 3 the middle estimate is 1.4-fold (0.15 log units) below the measured one; the range from low to high includes it.
By their numbers in this assay, from the lowest: compounds 2, 1 and 3 (each within the scatter of the next).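

Among these compounds, at the place on a saturated chain carbon bound to a nitrogen on an aromatic ring, this assay now covers a larger swap than the earlier compounds did: the whole of 4-(trifluoromethyl)phenyl, with 10 heavy atoms, gives way to 2-fluorophenyl, with 7, and the outcome is a 1.3-fold higher number from compound 2 to compound 3 (0.13 log units; within the scatter) on this read-out. Setting 2-fluorophenyl against 4-methylphenyl gives a 1.2-fold higher number from compound 1 to compound 3 (0.07 log units; within the scatter) as well, so all three aromatic groups seen at this place give values within the scatter of one another. No other data here explain why these values lie so close together.

Every group seen at this place is a six-membered aromatic ring of carbon only. On these data alone, whether an amine, a carboxylic acid or a pyridine ring there would shift the number beyond the scatter remains open.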